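Inverting one stereocentre of compound 2

The source may hold more compounds than are shown below. What is called first, only, known or untested is meant among the compounds shown, and "the series" means these compounds.

Among the compounds with values here, in an ADME assay on the whole organism (Rattus norvegicus, strain Sprague-Dawley), read by LC-MS, with a stated time of 30 min, at a dose of 1 mg/kg by the intravenous route (a higher number here means that the compound lasts longer, a lower number that the compound disappears faster), compound 2 `N#Cc1ccc(O[C@H]2CN(S(=O)(=O)c3ccc(Cl)cn3)C[C@@]2(O)CO)cc1F` gives 1.2 h, the higher of the two numbers so far, against compound 1 `N#Cc1ccc(O[C@H]2CN(S(=O)(=O)c3ccccc3C#N)C[C@@]2(O)CO)cc1F` at 0.4 h. That gap is a 3.0-fold higher number from compound 1 to compound 2 (0.48 log units; beyond the scatter), with 5-chloropyridin-2-yl in place of 2-cyanophenyl on a sulfonyl sulfur. Within the data shown here, compound 3 `N#Cc1ccc(O[C@H]2CN(S(=O)(=O)c3ccc(Cl)cn3)C[C@]2(O)CO)cc1F` keeps the 5-chloropyridin-2-yl and differs from compound 2 by the two compounds have the same atoms and bonds and differ only in configuration as drawn: 1 of 2 stereo elements differ; a stereocentre at a saturated ring carbon is drawn R in compound 2 and S in compound 3, a stereocentre at a saturated ring carbon drawn S rather than R. No measured step changes configuration, and the one available step gives no direction here. No change beyond the scatter is expected. The expected step is a 1.2-fold lower number from compound 2 to compound 3 (0.08 log units; within the scatter). The estimate for compound 3 is 1 h, within a range of 0.5 h to 2.2 h.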

Compound 3, mean residence time: 3.3 h
For compound 3 the middle estimate is 3.3-fold (0.52 log units) below the measured one; the whole stated range lies below it.
By their numbers in this assay, from the lowest: compound 1; then compound 2; then compound 3.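

In this assay drawing this saturated ring carbon S rather than R gives a 2.8-fold higher number from compound 2 to compound 3 (0.44 log units; beyond the scatter) with the 5-chloropyridin-2-yl held fixed. Within the data shown here, compound 1 and compound 2 showed only a change on the sulfonyl sulfur, so this is the first sign that the residence time responds to configuration in the shared core. The step has a single structural source: the fact that compounds 2 and 3 differ only in the configuration as drawn.

On these data alone, whether the S drawing gives a similar step with 2-cyanophenyl on the sulfonyl sulfur stays open. So does the outcome of replacing the hydroxymethyl with a carboxylic acid or a primary amine in this configuration.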